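From a carbamoyl to a benzamido end group

The source may report more compounds than this note shows. Statements on the series, on what has been measured and on what is new or still open speak of the compounds shown alone.

Among the compounds with values here, only two compounds with this core have been measured in a functional assay on PC-3 cells (Homo sapiens) for inhibition, read by sulforhodamine B assay, with a stated time of 48 h, tested at 50 uM; a higher number here means more inhibition of growth at the concentration tested, a lower number less inhibition of growth. Compound 2 (`COc1ccc([C@@H]2C/C(=N/OCc3cn(-c4ccc(C(N)=O)cc4)nn3)c3cc(CC=C(C)C)c(OC)cc3O2)cc1`) is the higher of the pair at 100%, and compound 1 (`COc1ccc([C@@H]2C/C(=N/OCc3cn(-c4ccc(C(=O)c5ccccc5)cc4)nn3)c3cc(CC=C(C)C)c(OC)cc3O2)cc1`) gives 40%.

Compound 3 (`COc1ccc([C@@H]2C/C(=N/OCc3cn(-c4ccc(NC(=O)c5ccccc5)cc4)nn3)c3cc(CC=C(C)C)c(OC)cc3O2)cc1`) differs from compound 2 in one place, with benzamido in place of carbamoyl on an aromatic carbon, para to a large group (benzamido in place of carbamoyl on an aromatic carbon). Within the data shown here, one measured step bears on this change: a number 60 percentage points higher from compound 1 to compound 2 (beyond the scatter). That large step came from amino in place of phenyl on a carbonyl carbon, at the same aromatic carbon. The benzamido group of compound 3 again holds a phenyl on a carbonyl carbon, as compound 1 does, so the result of compound 1 at 40% is the best available guide. However, the two groups are not the same, and no benzamido compound has been measured, so the evidence is thin.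

A large drop beyond the scatter is therefore expected, estimated as a number 50 percentage points lower from compound 2 to compound 3 (beyond the scatter). The estimate for compound 3 is 50%, with an expected range from 25% to 85%.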

Compound 3, percent growth inhibition at one concentration: 22%
Compound 3: middle estimate off by 28 percentage points, on the high side; the whole stated range lies above it.
By their numbers in this assay, from the lowest: compound 3; then compound 1; then compound 2.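

In this assay, replacing carbamoyl with benzamido on this aromatic carbon removes most of the growth inhibition, with a number 78 percentage points lower from compound 2 to compound 3 (beyond the scatter), even though the two groups have the same counts of hydrogen-bond donors and acceptors, so those counts do not track the result in this pair. The two end groups that carry a second six-membered aromatic ring are not interchangeable either: a number 18 percentage points lower from compound 1 to compound 3 (beyond the scatter), a modest step but one beyond the scatter, which separates benzamido from benzoyl at this carbon. Nothing shown here measures a property that would account for these gaps.

Still open, going by these compounds, is whether the added phenyl ring alone drives the fall: acetamido, with methyl in place of that phenyl, would separate the ring from the reversed amide link, and a carboxylic acid or a plain amine on the same carbon would show how much other small groups retain. On these data alone, since each number comes from a single concentration, it also remains open how these compounds would rank across a range of concentrations.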